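A few compounds are considered here, and "the series" means these few. Any claim that something is new, unique, unknown or untested is made for them only; others in the source may bear on it.

Compound 3 `COC(=O)NC[C@H]1CN(c2ccc(-n3cc(-c4ccccn4)cn3)c(F)c2)C(=O)O1`, which gives 71 ug/mL in an ADME assay on L02 cells (Homo sapiens) for cytotoxicity, read by MTT assay, with a stated time of 48 h (a higher number here means a weaker inhibitor, a lower number a stronger inhibitor), sits close to compound 1 `O=C1O[C@@H](CO)CN1c1ccc(-n2cc(-c3ccccn3)cn2)c(F)c1`, which in this assay gives 59 ug/mL; the two values lie within the scatter of each other, as a 1.2-fold higher number from compound 1 to compound 3 (0.08 log units; within the scatter) shows. For compound 2 `COC(=O)CC1CCN(C[C@H]2CN(c3ccc(-n4cc(-c5ccccn5)cn4)c(F)c3)C(=O)O2)CC1` this assay reports only a limit, > 400 ug/mL. That limit is the limit of > 400 ug/mL in this assay, at which 1 of the 3 values shown sits. The steps involving compound 2 were large: an at least 6.7-fold higher number from compound 1 to compound 2 (0.83 log units; beyond the scatter) and an at least 5.6-fold lower number from compound 2 to compound 3 (0.75 log units; beyond the scatter), both coming from exchange of the 4-((methoxycarbonyl)methyl)piperidin-1-yl group.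

Compound 4 `CONC(=O)[C@H]1CN(c2ccc(-n3cc(-c4ccccn4)cn3)c(F)c2)C(=O)O1` differs from compound 3 in one place: methoxycarbamoyl in place of ((methoxycarbonyl)amino)methyl on a saturated ring carbon. Among the measured steps, only the change from compound 1 to compound 3, which exchanged one small group on the saturated chain carbon bound to a saturated ring carbon for another and left the value within the scatter, resembles this one; the large steps all involved the 4-((methoxycarbonyl)methyl)piperidin-1-yl group. The step of a 1.0-fold lower number from compound 3 to compound 4 (0.01 log units; within the scatter) is therefore expected to stay within the scatter. Compound 4 is estimated at 70 ug/mL, between 35 ug/mL and 140 ug/mL.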

Compound 4, half-maximal inhibitory concentration: > 400 ug/mL
Compound 4 gave a limit, no number (the forecaster's own chance of this, stated with the estimate: 10%); middle value at least 5.7-fold (0.75 log units) from the limit.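

The earlier compounds shown here tied large steps in this assay only to the 4-((methoxycarbonyl)methyl)piperidin-1-yl group, but a small group on the saturated ring carbon next to the ring oxygen now produces one as well. Methoxycarbamoyl in place of ((methoxycarbonyl)amino)methyl gives an at least 5.6-fold higher number from compound 3 to compound 4 (0.75 log units; beyond the scatter), and in place of hydroxymethyl it gives an at least 6.7-fold higher number from compound 1 to compound 4 (0.83 log units; beyond the scatter), although the groups exchanged in the first step have equal counts of hydrogen-bond donors and acceptors. Compound 4 and compound 2 both stand at a limit, and the step between them cannot be read: the limit of > 400 ug/mL in this assay, at which 2 of the 4 values shown sit.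

From the compounds shown here alone, how far compound 4 lies beyond its limit remains open. Going by these compounds, it is also open which part of methoxycarbamoyl matters, a question that a primary carboxamide or a methyl ester on the same ring carbon would address.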